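Replacing an Isobutyl Ether with a Free Hydroxy Group

A few compounds are considered here, and "the series" means these few. Any claim that something is new, unique, unknown or untested is made for them only; others in the source may bear on it.

Three compounds of one family, compound 1 `O=c1c(/C=C/c2coc3ccccc3c2=O)coc2ccccc12`, compound 2 `CC(C)COc1cccc2occ(Cc3coc4ccccc4c3=O)c(=O)c12` and compound 3 `O=c1c(CCc2coc3ccccc3c2=O)coc2ccccc12`, have been tested in a functional assay on MDA-MB-231 cells (Homo sapiens) for antiproliferative activity, read by XTT assay; a lower number here means a stronger inhibitor, a higher number a weaker inhibitor. In this assay compound 1 gives > 10000 nM, which is a limit of the assay rather than a number. Compound 2 likewise gives > 10000 nM, again only a limit. Compound 3 gives > 10000 nM, also a limit. So compound 2 stands at the same place as the other two: all three sit at the limit of > 10000 nM in this assay, at which 3 of the 3 values shown sit, and no measured step between any pair is available.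

Compound 4 `O=c1c(Cc2coc3cccc(O)c3c2=O)coc2ccccc12` has not yet been measured. It differs from compound 2 by hydrogen in place of isobutyl on an oxygen on an aromatic ring. Within the data shown here, no measured pair shows what such a change does here, so the expectation rests only on the shared position of the three measured compounds. The step from compound 2 to compound 4 in this assay is expected to be a step that the limit leaves unreadable from compound 2 to compound 4, that is, no change beyond the usual scatter, due to every value shown sitting at the limit of > 10000 nM in this assay, at which 3 of the 3 values shown sit. Compound 4 is therefore estimated at 15000 nM, with a range from 4000 nM to 60000 nM.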

Compound 4, half-maximal inhibitory concentration: > 10000 nM
Compound 4: a limit, no number (the forecaster's own chance of this, stated with the estimate: 70%); the middle value lies beyond the limit too.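

Among these compounds, compound 2 and compound 4 both stop at a limit in this assay, so no step from isobutoxy to hydroxy can be read between them. The compounds shown leave open whether any member of this family gives a real number here, and what this change would do to such a number.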